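Swapping the thioether side chain at the aminopyridine core

The source may hold more compounds than are shown below. What is called first, only, known or untested is meant among the compounds shown, and "the series" means these compounds.

Three compounds share one core and differ only in the group carried on the saturated chain carbon bound to a sulfur. Compound 1 `N#Cc1c(N)nc(SCc2cccnc2)c(C#N)c1-c1ccc(OCC2CC2)cc1` bears a pyridin-3-yl there and gives 19% in an assay on CHO cells for displacement of a labelled ligand from adenosine receptor A3 (Homo sapiens), read by scintillation counting, with a stated time of 120 min, tested at 1 uM; on this read-out higher numbers stand for more inhibition at the one concentration tested (going by the name of the read-out) and lower numbers for less inhibition. Compound 2 `N#Cc1c(N)nc(SCc2cccc(C(N)=O)c2)c(C#N)c1-c1ccc(OCC2CC2)cc1` gives 1%, and compound 3 `COC(=O)c1cccc(CSc2nc(N)c(C#N)c(-c3ccc(OCC4CC4)cc3)c2C#N)c1` gives 4%. Among these three numbers compound 3 stands second highest: its nearest neighbour is compound 2, a gap that lies within the scatter, and its furthest is compound 1, which lies higher beyond the scatter.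

Both aryl replacements lowered the read-out: a number 18 percentage points lower from compound 1 to compound 2 (beyond the scatter) and a number 15 percentage points lower from compound 1 to compound 3 (beyond the scatter), whereas a number 3 percentage points higher from compound 2 to compound 3 (within the scatter) shows that the carbonyl substituent itself made no difference beyond the scatter.

Compound 4 `N#Cc1c(N)nc(SCC2=NCCN2)c(C#N)c1-c1ccc(OCC2CC2)cc1` is not yet measured. Relative to compound 3 the change is a group of 5 heavy atoms (3 carbon, 2 nitrogen; one five-membered non-aromatic ring with 2 hetero atoms) in place of a group of 10 heavy atoms (8 carbon, 2 oxygen; one six-membered aromatic ring of carbon only), on a saturated chain carbon bound to a sulfur. Among the compounds with values here, no measured step covers this kind of group at this position; the steps that bear on it show only that the substituted phenyl variants sit lower than the pyridin-3-yl of compound 1, and that the two carbonyl groups are interchangeable. The estimate therefore keeps compound 4 near compound 3, with a step of a number 4 percentage points higher from compound 3 to compound 4 (within the scatter) expected. Compound 4 is estimated at 8%, within a range from -8% to 28%.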

Compound 4, a percentage reported as inhibition, at one concentration (the size of the read-out at that concentration, not a potency): 6%
For compound 4 the middle estimate is 2 percentage points above the measured one; low and high end bracket the measured number.
By their numbers in this assay, from the lowest: compounds 2, 3 and 4 (each within the scatter of the next); then compound 1.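

In this assay the five-membered non-aromatic ring with 2 hetero atoms cannot be told apart from the substituted phenyl groups, with a number 2 percentage points higher from compound 3 to compound 4 (within the scatter) and a number 5 percentage points higher from compound 2 to compound 4 (within the scatter) both printed as within the scatter, so removing the six-membered aromatic ring of carbon only does not shift the number at this saturated chain carbon bound to a sulfur. With a number 13 percentage points lower from compound 1 to compound 4 (beyond the scatter) as a modest step, compound 1 and its pyridin-3-yl now stand apart from three quite different groups, and the lower level can no longer be tied to a substituted phenyl or to a carbonyl substituent. Nothing given here accounts for why these groups read as they do.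

The compounds shown leave open whether the higher number of compound 1 belongs to the pyridin-3-yl as such, as neither an unsubstituted phenyl nor a pyridin-4-yl at this place is among them. They also leave open how an open-chain amine, a carboxylic acid on the phenyl, or a longer chain between the sulfur and the ring would read at this one concentration.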